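A few compounds are considered here, and "the series" means these few. Any claim that something is new, unique, unknown or untested is made for them only; others in the source may bear on it.

Three anilides that share one core have been measured in an ADME assay for pharmacokinetics, read by LC-MS, in phosphate buffer, with a stated time of 120 min, at pH 7.4, tested at 1 uM, in the presence of a further agent that is not named here; a higher number here means that the compound lasts longer, a lower number that the compound disappears faster. Compound 1, `O=C(/C=C/CN1CCCC1)Nc1ccccc1`, gives 2.7 h in this assay. Compound 2, `O=C(O)C/C=C/C(=O)Nc1ccccc1`, reaches only the limit of the assay, > 8.53 h, which is not a number. Compound 3, `COC(=O)CN(C)C/C=C/C(=O)Nc1ccccc1`, likewise sits at the limit, > 8.53 h, so its exact position is not known; it stands at the limit of > 8.53 h in this assay, at which 2 of the 3 values shown sit, together with one other value. Among the measured compounds shown here, the one measured step, an at least 3.1-fold higher number from compound 1 to compound 2 (0.49 log units; beyond the scatter), concerns a different part of the chain and bears only indirectly on what follows.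

The unmeasured compound 4, `CN(C)C/C=C/C(=O)Nc1ccccc1`, differs from compound 3 by hydrogen in place of methoxycarbonyl on a saturated chain carbon bound to an amine nitrogen. With that change compound 4 comes to resemble compound 1, which carries a plain tertiary amine on the chain and gives 2.7 h in this assay. A step downward is therefore expected for compound 4, estimated as an at least 2.4-fold lower number from compound 3 to compound 4 (0.38 log units; beyond the scatter), though the limit on compound 3 makes its size uncertain. Compound 4 is expected to give about 3.5 h in this assay, within 1.5 h to 8.5 h.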

Compound 4, half-life: 1.93 h
Compound 4: middle estimate off by 1.8-fold (0.26 log units), on the high side; the measured number falls inside the stated range.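

Among the compounds shown here, removing the methoxycarbonyl from the saturated chain carbon bound to an amine nitrogen gives an at least 4.4-fold lower number from compound 3 to compound 4 (0.64 log units; beyond the scatter), so in this assay this position responds to the change even though the amine nitrogen stays in place, which the earlier compounds could not show. Dimethylamino in place of carboxy gives an at least 4.4-fold lower number from compound 2 to compound 4 (0.64 log units; beyond the scatter), the same direction as the earlier step with pyrrolidin-1-yl. The two amines are not separated, as dimethylamino in place of pyrrolidin-1-yl gives a 1.4-fold lower number from compound 1 to compound 4 (0.15 log units; within the scatter).

Compound 3 stands at a limit of the assay, not a number, which leaves the true size of its step open: the limit of > 8.53 h in this assay, at which 2 of the 4 values shown sit. The compounds shown also leave open whether a carboxylic acid or an amide in place of the methoxycarbonyl, or a longer chain carrying it, would last as long as compound 3 in this assay.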